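The source may hold more compounds than are shown below. What is called first, only, known or untested is meant among the compounds shown, and "the series" means these compounds.

Measured compounds

Compound 1, `ClCc1ccccc1Cn1cnc2c(Cl)nc(Cl)nc21`: 3980 nM in a functional assay on MDA-MB-231 cells (Homo sapiens) for cytotoxicity, read by sulforhodamine B assay, with a stated time of 48 h; on this read-out lower numbers stand for higher toxicity in this test and higher numbers for lower toxicity in this test
Compound 2, `ClCc1cccc(Cn2cnc3c(Cl)nc(Cl)nc32)c1`: 7240 nM in this assay
Compound 3, `Nc1nc(Cl)c2ncn(Cc3ccccc3CCl)c2n1`: 63100 nM in this assay

Compound 1 and compound 2 are built from the same atoms joined differently; the difference between the two cores is not broken down here. In this assay compound 2 gives 7240 nM and compound 1 gives 3980 nM, a gap that lies within the usual scatter, so no order between the two is claimed. Compound 3 stands apart: in this assay compound 3 gives 63100 nM, and the gap to compound 2 lies beyond the scatter.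

Among the measured compounds shown here, the one measured step is the change (amino in place of chloro on an aromatic carbon), which brought a 16-fold higher number from compound 1 to compound 3 (1.20 log units; beyond the scatter). The same change, made from compound 2, gives compound 4, `Nc1nc(Cl)c2ncn(Cc3cccc(CCl)c3)c2n1`, not yet measured in this assay; the change is amino in place of chloro on an aromatic carbon, and its surroundings read the same as for the step from compound 1 to compound 3, so it is taken as the same change. For the measured compounds named here, with only one measured instance of this change, the expectation for compound 4 rests on that instance alone, and the expected step from compound 2 to compound 4 is a 14-fold higher number from compound 2 to compound 4 (1.14 log units; beyond the scatter), set close to the measured step because of a 16-fold higher number from compound 1 to compound 3 (1.20 log units; beyond the scatter). On that basis, compound 4 is estimated at 100000 nM in this assay, expected to fall between 40000 nM and 300000 nM.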

Compound 4, concentration lethal to 50% of the cells: 69200 nM
Compound 4: the middle estimate sits 1.4-fold (0.16 log units) above what was measured, within the range that was stated.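

Carrying amino in place of chloro on an aromatic carbon over to the core of compound 2 brought a 9.6-fold higher number from compound 2 to compound 4 (0.98 log units; beyond the scatter) in this assay. Set beside the earlier instance of the same change, this step does not differ from it by more than the scatter allows, so the two cores give no reason to treat the change differently: the same change on two cores in this assay, a 16-fold higher number (1.20 log units; beyond the scatter) from compound 1 to compound 3 and a 9.6-fold higher number (0.98 log units; beyond the scatter) from compound 2 to compound 4, 1.7-fold (0.22 log units) apart, within the scatter of two such steps

Within these two pairs, then, the change carries from one core to the other with a step of comparable size and the same direction, but two instances do not establish a rule for other cores in the series, and the numbers alone give no explanation of why the step arises.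

The compounds shown leave open whether another group on the same carbon between two ring nitrogen atoms, such as a methylamine, a hydroxyl or a methoxy group, would also bring a higher number, or whether amino is a special case. Also open, as far as these compounds go, is what happens when the remaining chloro group on that ring gives way to an amine or a longer chain, and whether the chloromethyl group is needed for the values seen.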